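This account rests on a few compounds, and the source may have more. Where it says the series, first, only, none or still open, it means among the compounds named here.

Compounds measured:
compound 1 `COc1ccc(-c2nc(C)c(C(=O)CSc3nc(-c4ccc(Cl)cc4)c(C#N)c(=O)[nH]3)s2)cc1` — 102%
compound 2 `COc1ccc(-c2nc(C)c(C(=O)CSc3nc(-c4cccc(OC)c4)c(C#N)c(=O)[nH]3)s2)cc1` — 71.3%

In a functional assay on U-87MG ATCC cells for antiproliferative activity against U-87 MG (Homo sapiens), read by MTT assay, with a stated time of 48 h, tested at 5 uM (a lower number here means a stronger effect, a higher number a weaker effect of the compound at the concentration tested), compound 2 gives the lower of the two numbers; the step of a number 30.7 percentage points lower from compound 1 to compound 2 (beyond the scatter) is the only one measured. Compound 3 `COc1ccc(-c2nc(C)c(C(=O)CSc3nc(-c4ccc(OC)c(OC)c4)c(C#N)c(=O)[nH]3)s2)cc1` differs from compound 2 by methoxy in place of hydrogen on an aromatic carbon. Among the compounds with values here, no measured step covers adding a second methoxy to this ring; the step from compound 1 to compound 2 changed the whole aryl group and is only loosely related. A step of modest size is expected, a number 6.3 percentage points lower from compound 2 to compound 3 (within the scatter), with direction uncertain and near the scatter. For compound 3 the estimate is 65%, within 45% to 90%.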

Compound 3, a percentage reported as activity, at one concentration (the size of the read-out at that concentration, not a potency): 81.2%
Compound 3: middle estimate off by 16.2 percentage points, on the low side; measured number inside the range.
By their numbers in this assay, from the lowest: compounds 2 and 3 (each within the scatter of the next); then compound 1.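

In this assay, methoxy in place of hydrogen on the 3-methoxyphenyl ring gives a number 9.9 percentage points higher from compound 2 to compound 3 (within the scatter), so the second methoxy, ortho to the first, does not separate 3,4-dimethoxyphenyl from 3-methoxyphenyl here. The 3,4-dimethoxyphenyl group still differs from 4-chlorophenyl, with a number 20.8 percentage points lower from compound 1 to compound 3 (beyond the scatter), so the gap to compound 1 is not confined to the single-methoxy ring. No available evidence bears on the reason for these steps.

Open, on these data alone, is whether an amine or a carboxylic acid at this position on the ring would move the number beyond the scatter. Also open, as far as these compounds go, is what a longer chain, such as ethoxy in place of methoxy, would do.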